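This account rests on a few compounds, and the source may have more. Where it says the series, first, only, none or still open, it means among the compounds named here.

Measured in an in vivo ADME assay on the whole organism for pharmacokinetics, with Rattus norvegicus as the target, at a dose of 1 mg/kg by the intravenous route; on this read-out higher numbers stand for wider distribution into tissues and lower numbers for narrower distribution:
- compound 1 `O=C(O)c1cccc(C2=C(c3cc(Br)ccc3OCc3ccc(F)cc3)CCC2)c1`: 0.7 L/kg
- compound 2 `O=C(O)c1cccc(C2=C(c3cc(Cl)ccc3OCc3ccccc3)CCC2)c1`: 0.8 L/kg

Compound 1, at 0.7 L/kg, lies within the usual scatter of compound 2, at 0.8 L/kg, so the two values cannot be separated. Next in line is compound 3 `O=C(O)c1cccc(C2=C(c3cc(Br)ccc3OCc3ccccc3)CCC2)c1`, which has not yet been measured in this assay. It differs from compound 1 in one place: hydrogen in place of fluoro on an aromatic carbon. This is hydrogen in place of fluoro on an aromatic carbon, para to a large group, so 4-fluorobenzyl becomes benzyl. Among the compounds with values here, no single-place step between measured compounds is available to size this change, so no step beyond the scatter is expected, and no direction is favoured. The estimated step, a 1.1-fold higher number from compound 1 to compound 3 (0.03 log units; within the scatter), stays within the scatter. For compound 3 the estimated value is 0.75 L/kg, with an expected range of 0.4 L/kg to 1.3 L/kg.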

Compound 3, volume of distribution at steady state: 1 L/kg
Compound 3: the middle estimate sits 1.3-fold (0.12 log units) below what was measured, within the range that was stated.
By their numbers in this assay, from the lowest: compounds 1, 2 and 3 (each within the scatter of the next).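

In this assay, the change from 4-fluorobenzyl to benzyl now has a measured size: a 1.4-fold higher number from compound 1 to compound 3 (0.15 log units; within the scatter) shows that fluoro and hydrogen on this aromatic carbon, para to a large group, cannot be told apart on this read-out. The second single-place pair, with bromo in place of chloro on an aromatic carbon, gives a 1.3-fold higher number from compound 2 to compound 3 (0.10 log units; within the scatter) and likewise leaves the two halogens unseparated. Nothing at hand bears on the cause of either step.

On these data alone, whether an amine or a nitrile on the same aromatic carbon would give a step beyond the scatter stays open. Also open, as far as these compounds go, is whether an amide in place of the carboxylic acid on the shared core would shift the volume of distribution beyond the scatter.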